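Pyridyl shift on the exocyclic double bond: compound 3 expected

A few compounds are considered here, and "the series" means these few. Any claim that something is new, unique, unknown or untested is made for them only; others in the source may bear on it.

Compound 1 `COc1ccccc1C=C1CCN(c2ccc(C(=O)NS(=O)(=O)c3ccc(N[C@H](CCN(C)C)CSc4ccccc4)c([N+](=O)[O-])c3)cc2)CC1` gives 2 nM in an assay on isolated protein for displacement of a labelled ligand from Apoptosis regulator Bcl-2 (Homo sapiens), read by fluorescence polarization; on this read-out lower numbers stand for stronger inhibition and higher numbers for weaker inhibition.
Compound 2 `CN(C)CC[C@H](CSc1ccccc1)Nc1ccc(S(=O)(=O)NC(=O)c2ccc(N3CCC(=Cc4ccccn4)CC3)cc2)cc1[N+](=O)[O-]` gives 46 nM in this assay.

Among the measured compounds shown here, of the two measured compounds, compound 2 stands at the higher number in this assay; the only neighbour, compound 1, lies at the lower one, and the single measured step, a 23-fold higher number from compound 1 to compound 2 (1.36 log units; beyond the scatter), is a large loss at the aryl group on the exocyclic double bond.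

Compound 3 `CN(C)CC[C@H](CSc1ccccc1)Nc1ccc(S(=O)(=O)NC(=O)c2ccc(N3CCC(=Cc4cccnc4)CC3)cc2)cc1[N+](=O)[O-]` is not yet measured. It differs from compound 2 by pyridin-3-yl in place of pyridin-2-yl on a double-bonded chain carbon bound to a double-bonded ring carbon. For the measured compounds named here, no measured pair shows this particular move of the ring nitrogen; the one step that touches the same place, a 23-fold higher number from compound 1 to compound 2 (1.36 log units; beyond the scatter), compares two different aryl groups and so gives only a loose sense of how sensitive this position is. Since the ring stays a pyridyl and only its nitrogen moves, the step from compound 2 to compound 3 is expected to be small, within or near the scatter, with the direction undecided: a 1.2-fold lower number from compound 2 to compound 3 (0.06 log units; within the scatter). Compound 3 is therefore expected to give about 40 nM in this assay, within a range of 10 nM to 160 nM.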

Compound 3, inhibition constant: 68 nM
Compound 3: the middle estimate sits 1.7-fold (0.23 log units) below what was measured; the measured number falls inside the stated range.
By their numbers in this assay, from the lowest: compound 1; then compounds 2 and 3 (each within the scatter of the next).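

In this assay, moving the ring nitrogen leaves the read-out within the scatter (a 1.5-fold higher number from compound 2 to compound 3 (0.17 log units; within the scatter)), so pyridin-2-yl and pyridin-3-yl cannot be told apart on a double-bonded chain carbon bound to a double-bonded ring carbon. Against 2-methoxyphenyl, pyridin-3-yl gives a large step (a 34-fold higher number from compound 1 to compound 3 (1.53 log units; beyond the scatter)), as pyridin-2-yl does (a 23-fold higher number from compound 1 to compound 2 (1.36 log units; beyond the scatter)), so the gap to compound 1 is now seen with both pyridyl groups and does not belong to a single placement of the ring nitrogen. Nothing available explains either the large steps or the lack of a distinguishable difference between the two pyridyl compounds.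

The compounds shown leave open whether the gap to compound 1 goes with the ring nitrogen or with the missing methoxy group, as both differ at once in each large step; a plain phenyl group and a methoxy-bearing pyridin-3-yl group at this place would separate the two. They also leave open whether pyridin-4-yl would stay level with the two pyridyl groups shown here.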